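The source may hold more compounds than are shown below. What is called first, only, known or untested is meant among the compounds shown, and "the series" means these compounds.

Three compounds share one core and differ only in the group on an amine nitrogen: compound 1 `CC(C)(C)C(=O)N(CCCCCCN1C[C@H](O)[C@@H](O)[C@H](O)[C@H]1CO)C1CCCCC1`, compound 2 `O=C(c1cc(F)c(F)cc1F)N(CCCCCCN1C[C@H](O)[C@@H](O)[C@H](O)[C@H]1CO)C1CCCCC1` and compound 3 `CS(=O)(=O)N(CCCCCCN1C[C@H](O)[C@@H](O)[C@H](O)[C@H]1CO)C1CCCCC1`. All three were tested in an ADME assay on MDBK cells (Bos taurus) for cytotoxicity, read by MTT assay; a lower number here means that less compound is tolerated, a higher number that more compound is tolerated. Compound 1 gives > 500000 nM, which is a limit of the assay and not a number. Compound 2 gives > 500000 nM, again a limit. Compound 3 gives > 500000 nM, also a limit, so it has no exact value to start from. Among the measured compounds shown here, the whole series so far comes down to the limit of > 500000 nM in this assay, at which 3 of the 3 values shown sit.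

Compound 4 `CC(C)(C)S(=O)(=O)N(CCCCCCN1C[C@H](O)[C@@H](O)[C@H](O)[C@H]1CO)C1CCCCC1` has tert-butyl in place of methyl on a sulfonyl sulfur. For the measured compounds named here, no measured step makes this exact change. The nearest evidence is a step that the two limits leave unreadable from compound 1 to compound 3, alongside a step that the two limits leave unreadable from compound 2 to compound 3 and a step that the two limits leave unreadable from compound 1 to compound 2, so none of the three gives a size to carry over. Still, compound 1 already carries tert-butyl, on a carbonyl carbon, and its reading is the limit > 500000 nM.

No step beyond the usual scatter is therefore expected in this assay, and no direction can be named. The expected change is a number no higher from compound 3 to compound 4 (the limit leaves the size open). For compound 4 the estimate is 500000 nM, with an expected range from 250000 nM to 1000000 nM, and the assay will probably report only a limit again.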

Compound 4, half-maximal cytotoxic concentration: > 500000 nM
Compound 4: only a limit was reported (the forecaster's own chance of this, stated with the estimate: 90%); the middle value lies on the limit itself.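

Compound 4 gives > 500000 nM in this assay, which is a limit and not a number. The steps to compound 4 from compound 1, compound 2 and compound 3 therefore cannot be read. The compounds shown leave open how much of each one the cells tolerate, and whether changing the group on the amine nitrogen alters that at all: the limit of > 500000 nM in this assay, at which 4 of the 4 values shown sit.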